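The compounds below may be only part of what the source reports. "The series", "measured", "known", "first", "only" and "open" are said of these compounds alone.

Compound 1 `COc1cccc(C(=O)N[C@@H](CCC2CCCCC2)C(=O)N[C@H](CN2CCc3cc(F)ccc32)C(C)C)c1` gives 14 nM in an assay on isolated protein for inhibition of cathepsin S (Homo sapiens); on this read-out lower numbers stand for stronger inhibition and higher numbers for weaker inhibition.
Compound 2 `COc1cccc(C(=O)N[C@@H](CCC2CCCCC2)C(=O)N[C@@H](CC(C)C)CN2CCc3cc(F)ccc32)c1` gives 28 nM in this assay.

Compound 2 sits at one end of the two numbers shown, yet the step of a 2.0-fold higher number from compound 1 to compound 2 (0.30 log units; within the scatter) lies within the scatter, so the two compounds cannot be told apart on these data. Compound 3 `COc1cccc(C(=O)N[C@@H](CCC2CCCCC2)C(=O)N[C@@H](CO)CN2CCc3cc(F)ccc32)c1` has not been measured. It differs from compound 2 by hydroxy in place of isopropyl on a saturated chain carbon, two bonds along the chain from an amide-type nitrogen. Among the compounds with values here, the only measured step, a 2.0-fold higher number from compound 1 to compound 2 (0.30 log units; within the scatter), swapped one alkyl group for another and left the number essentially where it was; it bears only loosely on the present change, which takes away three carbons and brings in a hydrogen-bond donor and acceptor. Within the data shown here, no measured compound carries such a group, so the direction of the step is uncertain, and a modestly higher number is expected, a 2.9-fold higher number from compound 2 to compound 3 (0.46 log units; beyond the scatter), with wide uncertainty. Compound 3 is estimated at 80 nM, in the range 20 nM to 400 nM.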

Compound 3, inhibition constant: 50 nM
Compound 3: the middle estimate sits 1.6-fold (0.20 log units) above what was measured; the range from low to high includes it.
By their numbers in this assay, from the lowest: compounds 1, 2 and 3 (each within the scatter of the next, the first and the last beyond it).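

Putting hydroxy in place of isopropyl on a saturated chain carbon, two bonds along the chain from an amide-type nitrogen, brings a hydrogen-bond donor and acceptor into this series, yet in this assay the result is a 1.8-fold higher number from compound 2 to compound 3 (0.25 log units; within the scatter) and the two cannot be told apart. Within the data shown here, the swap of isopropyl for hydroxymethyl gives the first step here that clears the scatter, a 3.6-fold higher number from compound 1 to compound 3 (0.55 log units; beyond the scatter) and it is only a modest one. No measurement shown offers an explanation for either step.

As far as these compounds go, it remains open how this position would respond to a methoxymethyl group, which keeps the oxygen but lacks the hydroxy hydrogen. An aminomethyl group or a carboxylic acid in the same place is equally uncharted.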